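The source may report more compounds than this note shows. Statements on the series, on what has been measured and on what is new or still open speak of the compounds shown alone.

Measured so far in an ADME assay on Vero cells (Chlorocebus sabaeus) for cytotoxicity; on this read-out higher numbers stand for lower toxicity in this test and lower numbers for higher toxicity in this test:
compound 1, `COc1ccc(-c2nc3c(C(=O)Nc4ncc[nH]4)cccc3[nH]2)cc1OC`: "not active" (no number reported), with no number reported
compound 2, `COc1ccc(-c2nc3c(C(=O)Nc4cnccn4)cccc3[nH]2)cc1OC`: 98.8 uM
compound 3, `COc1ccc(-c2nc3c(C(=O)Nc4nc5ccccc5[nH]4)cccc3[nH]2)cc1OC`: 51.8 uM

All three share one core and differ only in the group attached to the amide-type nitrogen. Compound 1 gave no number in this assay. Compound 2 and compound 3 did, and the step between them, a 1.9-fold lower number from compound 2 to compound 3 (0.28 log units; within the scatter), is small enough to count as noise, so the two cannot be placed in any order on this read-out.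

Compound 4, `COc1ccc(-c2nc3c(C(=O)Nc4ncccc4O)cccc3[nH]2)cc1OC`, has not yet been measured. It differs from compound 3 in one place: 3-hydroxypyridin-2-yl in place of 1H-benzimidazol-2-yl on an amide-type nitrogen.

Going by the values given here, only one measured step bears on this change, the exchange of one ring group for another on the same amide-type nitrogen from compound 2 to compound 3, and that step stayed within the scatter. On that basis the number for compound 4 is expected to stay close to that of compound 3, with no step beyond the scatter in either direction, so the estimated step is a 1.2-fold higher number from compound 3 to compound 4 (0.06 log units; within the scatter). The estimate for compound 4 in this assay is 60 uM, with a range from 25 uM to 150 uM.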

Compound 4, half-maximal toxic concentration: 164 uM
The estimate for compound 4 lay 2.7-fold (0.44 log units) below the measured number; measured number outside the range, above it.
By their numbers in this assay, from the lowest: compounds 3, 2 and 4 (each within the scatter of the next, the first and the last beyond it).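

In this assay, going by these compounds alone, the group on the amide-type nitrogen can move the number beyond the scatter: 3-hydroxypyridin-2-yl in place of 1H-benzimidazol-2-yl gives a 3.2-fold higher number from compound 3 to compound 4 (0.50 log units; beyond the scatter), a modest step and the only one among the measured pairs to clear the scatter. The reach of this change is narrow, however, since 3-hydroxypyridin-2-yl in place of pyrazin-2-yl gives a 1.7-fold higher number from compound 2 to compound 4 (0.22 log units; within the scatter), which stays within the scatter and leaves those two compounds without an order. So the new group stands apart from 1H-benzimidazol-2-yl on this read-out, but not from every ring tried at this position.

The change from compound 3 to compound 4 swaps a two-ring group for a one-ring group and also brings in an oxygen, and the compounds shown include neither a plain pyridin-2-yl without the hydroxy group nor a pyridine carrying a methoxy or an amine in its place, so the part of the change that matters stays unresolved. No measurement here offers an explanation for the step.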